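The compounds below may be only part of what the source reports. "The series", "measured", "known", "first", "only" and "open" are said of these compounds alone.

Four related compounds are compared in a functional assay on HCT-116 cells (Homo sapiens), read by MTT assay, with a stated time of 72 h; on this read-out higher numbers stand for weaker inhibition and lower numbers for stronger inhibition. Compound 1 `CSc1ncnc2c1c(-c1ccsc1)cn2[C@@H]1O[C@H](CO)[C@@H](O)[C@H]1O` gives > 20000 nM, which is a limit of the assay and not a number. Compound 2 `Cc1ncnc2c1c(-c1cc3ccccc3o1)cn2[C@@H]1O[C@H](CO)[C@@H](O)[C@H]1O` gives > 20000 nM, again only a limit. Compound 3 `Nc1nc(N)c2c(-c3cccs3)cn([C@@H]3O[C@H](CO)[C@@H](O)[C@H]3O)c2n1` gives > 20000 nM, also a limit and not a number. Compound 3 therefore has no exact position and shares its reading with the other two: the limit of > 20000 nM in this assay, at which 3 of the 3 values shown sit.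

Compound 4 `Nc1nc(N)c2c(-c3cc4ccccc4o3)cn([C@@H]3O[C@H](CO)[C@@H](O)[C@H]3O)c2n1` keeps the core of compound 3 but has 1-benzofuran-2-yl in place of thiophen-2-yl on an aromatic carbon. Going by the values given here, no two measured compounds differ in only one place, so no measured step shows the size of this change. The closest guide is compound 2, which carries the same 1-benzofuran-2-yl and gives > 20000 nM, a limit as well. On that basis, no change beyond the usual scatter is expected. The estimated step of a number no higher from compound 3 to compound 4 (the limit leaves the size open) is expected to be small. For compound 4 the estimated value is 20000 nM, with an expected range from 6000 nM to 40000 nM.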

Compound 4, half-maximal inhibitory concentration: > 20000 nM
Compound 4 was reported as a limit (the forecaster's own chance of this, stated with the estimate: 75%); the middle value lies on the limit itself.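

Going by these compounds alone, compound 3 and compound 4 each give only a limit of the assay and not a number, and no step between them can be read. The compounds shown leave open whether any change in their groups alters inhibition in this assay, as all share one reading: the limit of > 20000 nM in this assay, at which 4 of the 4 values shown sit.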